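The source may report more compounds than this note shows. Statements on the series, on what has been measured and on what is new or still open speak of the compounds shown alone.

Among the compounds with values here, compound 2, with the structure `C[C@@H](NC(=O)c1ccc(C#Cc2cc(F)ccn2)cn1)C(C)(C)O`, is one of two compounds measured so far in an ADME assay on HEK293 cells for agonist activity at metabotropic glutamate receptor 5 (Rattus norvegicus), read by fluorescence and calcium flux (a higher number here means a larger maximal response, a lower number a smaller maximal response), in which compound 2 gives 33%. The other, compound 1 with the structure `Cc1ccccc1C#Cc1ccc(C(=O)N[C@H](C)C(C)(C)O)nc1`, gives 24.1% in this assay. The two differ only in the group on a triple-bonded carbon, and the step of a number 8.9 percentage points higher from compound 1 to compound 2 (within the scatter) lies within the scatter, so the two values cannot be told apart with confidence.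

Compound 3, with the structure `C[C@@H](NC(=O)c1ccc(C#Cc2ncccc2F)cn1)C(C)(C)O`, has not yet been measured. It differs from compound 2 as follows: 3-fluoropyridin-2-yl in place of 4-fluoropyridin-2-yl on a triple-bonded carbon. The two groups have the same atoms, joined differently. Within the data shown here, no measured step involves a change of this kind; the only step available, a number 8.9 percentage points higher from compound 1 to compound 2 (within the scatter), replaced a 2-methylphenyl by a 4-fluoropyridin-2-yl and stayed within the scatter. There is therefore no basis to expect a step beyond the scatter in this assay in either direction. Compound 3 is expected to give about 30% in this assay, between 15% and 50%, which means an expected step of a number 3 percentage points lower from compound 2 to compound 3 (within the scatter).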

Compound 3, largest response reached (reported as efficacy), in percent of the reference or control that the assay uses: 29.2%
Beside the measured number, compound 3's estimate is 0.8 percentage points above it; measured number inside the range.
By their numbers in this assay, from the lowest: compounds 1, 3 and 2 (each within the scatter of the next).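

Within the data shown here, exchanging 4-fluoropyridin-2-yl for 3-fluoropyridin-2-yl on a triple-bonded carbon is the first change here that keeps the same atoms and joins them differently, and in this assay the step is a number 3.8 percentage points lower from compound 2 to compound 3 (within the scatter). This rearrangement therefore does not separate the two compounds. Exchanging 2-methylphenyl for 3-fluoropyridin-2-yl gives a step of a number 5.1 percentage points higher from compound 1 to compound 3 (within the scatter), so all three groups at this position now lie within the scatter of one another, and no measurement shown explains why they read alike.

These three compounds leave open whether a very different group on the triple-bonded carbon, such as a cyclohexyl or a plain methyl, or a pyridin-2-yl without fluorine, would give a step beyond the scatter. They also leave open whether the same flat picture would hold if the shared core were changed elsewhere, for example if the hydroxyl group on its chain were replaced by an amine.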